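The compounds below may be only part of what the source reports. "The series", "measured", "known", "first", "only" and "open" are said of these compounds alone.

Among the compounds with values here, in a functional assay on DU-145 cells (Homo sapiens) for cytotoxicity, read by MTT assay, with a stated time of 48 h (on this read-out higher numbers stand for weaker inhibition and lower numbers for stronger inhibition), three compounds have numbers so far. Compound 1 (`COc1cc(COCc2cn(Cc3cc(C)cnc3Cl)nn2)cc(OC)c1OC`) gives 34800 nM, compound 2 (`COc1cc(-c2cc(COCc3cn(Cc4cc(-c5ccccc5)cnc4Cl)nn3)on2)cc(OC)c1OC`) gives 78500 nM, and compound 3 (`COc1cc(-c2cc(COCc3cn(Cc4cc(-c5ccc(C)cc5)cnc4Cl)nn3)on2)cc(OC)c1OC`) gives 37300 nM. Compound 2 therefore has the highest of the three numbers, and both other compounds lie beyond the scatter from it.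

The next comparison leads from compound 2 to compound 4 (`COc1cc(-c2cc(COCc3cn(Cc4cc(C)cnc4Cl)nn3)on2)cc(OC)c1OC`), which has not yet been measured: methyl in place of phenyl on an aromatic carbon. This is methyl in place of phenyl on an aromatic carbon, para to a chloro group.

Within the data shown here, only one measured step bears on this change, and only loosely. It is a 2.1-fold lower number from compound 2 to compound 3 (0.32 log units; beyond the scatter), a modest step in which methyl takes the place of hydrogen on an aromatic carbon while the phenyl stays. The methyl of compound 4 also occurs on a different core in compound 1, and compound 1 stands at 34800 nM. Neither comparison shows what removing the phenyl does by itself, so the expectation is loose. A modest move towards a lower number in this assay is expected, with an estimated 2.0-fold lower number from compound 2 to compound 4 (0.29 log units; within the scatter). For compound 4 the expected value is 40000 nM, with an estimated range from 16000 nM to 90000 nM.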

Compound 4, half-maximal inhibitory concentration: 39800 nM
For compound 4 the middle estimate is 1.0-fold (0.00 log units) above the measured one; low and high end bracket the measured number.
By their numbers in this assay, from the lowest: compounds 1, 3, 4 and 2 (each within the scatter of the next, the first and the last beyond it).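

In this assay, the position para to a chloro group accepts methyl in place of phenyl with no readable effect: a 2.0-fold lower number from compound 2 to compound 4 (0.29 log units; within the scatter). Methyl in place of 4-methylphenyl gives the same picture, with a 1.1-fold higher number from compound 3 to compound 4 (0.03 log units; within the scatter), so neither aromatic ring of carbon only is needed at this position to keep the number where it stands. Until now the only readable change here was the step on the phenyl ring itself, a 2.1-fold lower number from compound 2 to compound 3 (0.32 log units; beyond the scatter), which lies beyond the scatter; compound 4 lies within the scatter of both of these compounds, so the compounds with and without a ring at this position cannot be told apart.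

Nothing among the data shown gives a reason for this outcome. On these data alone, it remains open whether a group of another kind at this position, such as an amine, a carboxylic acid or a longer chain, would move the number beyond the scatter from compound 4, since only methyl, phenyl and 4-methylphenyl are compared here.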